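Furan substituent growth: isopropyl to cyclohexyl

A few compounds are considered here, and "the series" means these few. Any claim that something is new, unique, unknown or untested is made for them only; others in the source may bear on it.

For the measured compounds named here, compound 3 `CC[C@@H](Nc1c(Nc2cccc(C(=O)N(C)C)c2O)c(=O)c1=O)c1cc(C(C)C)co1` gives 3 nM in an assay on CHO cells for displacement of a labelled ligand from C-X-C chemokine receptor type 1 (Homo sapiens) (a lower number here means a stronger inhibitor, a higher number a weaker inhibitor), the lowest of the three numbers measured so far; compound 2 `CCc1coc([C@@H](CC)Nc2c(Nc3cccc(C(=O)N(C)C)c3O)c(=O)c2=O)c1` gives 7 nM and compound 1 `CC[C@@H](Nc1c(Nc2cccc(C(=O)N(C)C)c2O)c(=O)c1=O)c1cc(C)co1` gives 9 nM. Compound 4 `CC[C@@H](Nc1c(Nc2cccc(C(=O)N(C)C)c2O)c(=O)c1=O)c1cc(C2CCCCC2)co1` carries the change (cyclohexyl in place of isopropyl on an aromatic carbon). Going by the values given here, two measured steps bear on it, both enlarging the group on the same aromatic carbon: a 3.0-fold lower number from compound 1 to compound 3 (0.48 log units; beyond the scatter) and a 2.3-fold lower number from compound 2 to compound 3 (0.37 log units; beyond the scatter), each a modest gain toward a lower number. Growing further to cyclohexyl may continue this or level off, so in this assay a step of about a 1.5-fold lower number from compound 3 to compound 4 (0.18 log units; within the scatter) is expected, toward a lower number if anything, and not far beyond the scatter. Compound 4 is therefore estimated at 2 nM, with a range from 0.7 nM to 6 nM.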

Compound 4, inhibition constant: 283 nM
For compound 4 the middle estimate is 140-fold (2.15 log units) below the measured one; measured number above the stated range.
By their numbers in this assay, from the lowest: compound 3; then compounds 2 and 1 (each within the scatter of the next); then compound 4.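

In this assay, growth on this aromatic carbon has a limit that the methyl, ethyl and isopropyl compounds did not show: cyclohexyl reverses the earlier gains (a 94-fold higher number from compound 3 to compound 4 (1.97 log units; beyond the scatter)). The loss also stands against the smaller groups (a 40-fold higher number from compound 2 to compound 4 (1.61 log units; beyond the scatter); a 31-fold higher number from compound 1 to compound 4 (1.50 log units; beyond the scatter)). Nothing at hand gives a reason for this reversal.

Open, as far as these compounds go, is whether the ring or the carbon count drives the loss. A cyclopropyl, a tert-butyl or an open hexyl chain on this carbon would separate the two, and a tetrahydropyran ring would test a ring oxygen.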